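This account rests on a few compounds, and the source may have more. Where it says the series, first, only, none or still open, it means among the compounds named here.

Measured compounds:
Compound 1, `O=C(Nc1ccc(CN2CCCCC2)cc1)Nc1ccc2ncnc(Nc3cccc(C(F)(F)F)c3)c2c1`, gives 1050 nM in a functional assay on A549 cells (Homo sapiens) for antiproliferative activity, read by MTT assay, with a stated time of 72 h; a higher number here means a weaker inhibitor, a lower number a stronger inhibitor.
Compound 2, `COc1ccc(NC(=O)Nc2ccc3ncnc(Nc4cccc(C(F)(F)F)c4)c3c2)cc1`, gives 9470 nM in this assay.

Among the compounds with values here, compound 2 stands at the top of the two numbers known so far, which here means it is the weaker inhibitor of the pair. Within the data shown here, the only step measured is a 9.0-fold higher number from compound 1 to compound 2 (0.96 log units; beyond the scatter), and it goes the wrong way for potency: swapping the piperidinylmethyl group for a methoxy group cost a clear amount, beyond the scatter of repeated runs.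

Compound 3, `CN1CCN(c2ccc(NC(=O)Nc3ccc4ncnc(Nc5cccc(C(F)(F)F)c5)c4c3)cc2)CC1`, has not been measured yet. It differs from compound 2 in one place: 4-methylpiperazin-1-yl in place of methoxy on an aromatic carbon. This is not a simple reversal of the measured step, but it does put a ring-bearing, two-nitrogen group back where the small methoxy group sits in compound 2. Among the measured compounds shown here, because the loss of such a group gave a 9.0-fold higher number from compound 1 to compound 2 (0.96 log units; beyond the scatter), compound 3 is expected to regain a good part of that ground, so a drop in this assay of roughly a 6.3-fold lower number from compound 2 to compound 3 (0.80 log units; beyond the scatter) is anticipated, though with real uncertainty since only one step supports it. The estimate for compound 3 is 1500 nM, with a likely range from 450 nM to 5000 nM.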

Compound 3, half-maximal inhibitory concentration: 2760 nM
Compound 3: middle estimate off by 1.8-fold (0.26 log units), on the low side; the measured number falls inside the stated range.
By their numbers in this assay, from the lowest: compound 1; then compound 3; then compound 2.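

In this assay, the step gives a 3.4-fold lower number from compound 2 to compound 3 (0.54 log units; beyond the scatter), which shows that this place, para to a large group, can take a much larger group than methoxy and still improve on it: 4-methylpiperazin-1-yl brings a six-membered non-aromatic ring with 2 hetero atoms onto the same aromatic carbon. The gain is only partial, however, as the comparison with the other ring-bearing group gives a 2.6-fold higher number from compound 1 to compound 3 (0.42 log units; beyond the scatter), so 4-methylpiperazin-1-yl and (piperidin-1-yl)methyl are not interchangeable here, even though both give lower numbers than methoxy. No available measurement explains either difference.

Compound 1 and compound 3 differ both in the ring and in whether a methyl link joins it to the aromatic ring, so the compounds shown cannot separate these two features; a (4-methylpiperazin-1-yl)methyl group would bear directly on that question. As far as these compounds go, it also remains open how a ring with an oxygen atom, such as morpholin-4-yl, or a simple open-chain amine such as dimethylamino, would behave at this same place.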